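Hydroxy to methoxy on the shared core

This account rests on a few compounds, and the source may have more. Where it says the series, first, only, none or still open, it means among the compounds named here.

Measured in a functional assay on Jurkat cells (Homo sapiens) for cytotoxicity; a lower number here means a stronger inhibitor, a higher number a weaker inhibitor:
- compound 1 `C/C=C/C1=C(CO)[C@H](O)[C@H]2O[C@H]2C1=O` gives > 80000 nM
- compound 2 `C/C=C/C1=C(CO)[C@@H](O)[C@@H]2O[C@@H]2C1=O` gives 60000 nM

The reading for compound 1, > 80000 nM, is a limit and not a number.

Compound 3 `C/C=C/C1=C(CO)[C@H](OC)[C@H]2O[C@H]2C1=O` carries methyl in place of hydrogen on an oxygen on a saturated carbon, which reads as hydroxy to methoxy on the core of compound 1. For the measured compounds named here, the only measured step is an at least 1.3-fold lower number from compound 1 to compound 2 (0.12 log units; that floor lies within the scatter). It rests on the limit of > 80000 nM in this assay, at which 1 of the 2 values shown sits, and involves (the fact that compounds 1 and 2 differ only in the configuration as drawn), so it gives no size for a methyl in place of hydrogen. Going by the values given here, the only actual number is compound 2 at 60000 nM, and the expectation stays in that region. No step beyond the scatter is expected in this assay, and the expected step is a number no higher from compound 1 to compound 3 (the limit leaves the size open). Compound 3 is estimated at 80000 nM, with an expected range of 25000 nM to 160000 nM.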

Compound 3, half-maximal inhibitory concentration: > 80000 nM
Compound 3: only a limit was reported; the forecaster's own chance of this, stated with the estimate: 50%; the middle value sits exactly at the limit.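

In this assay compound 3 gives > 80000 nM, which is a limit and not a number. For the compounds shown here, compound 1 also stands only at a limit, and no step between compound 1 and compound 3 can be read. The compounds shown leave open what size, if any, hydroxy to methoxy has on the shared core.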